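A few compounds are considered here, and "the series" means these few. Any claim that something is new, unique, unknown or untested is made for them only; others in the source may bear on it.

Working notes on the series.

Among the compounds with values here, compound 2 `C[C@H](c1ccc(C(=O)NCCC(=O)O)cc1)N1C(=O)C(c2ccccc2F)=N[C@]12CC[C@@H](C(C)(C)C)CC2` gives 350 nM in a functional assay on CHO cells for antagonist activity at Glucagon receptor (Homo sapiens), read by cAMP accumulation, with stated times of 30 min and 45 min (on this read-out lower numbers stand for stronger inhibition and higher numbers for weaker inhibition), and stands at the lowest of the two numbers so far, with compound 1 `C[C@H](c1ccc(C(=O)NCCC(=O)O)cc1)N1C(=O)C(c2cccc(F)c2)=N[C@]12CC[C@@H](C(C)(C)C)CC2` as its nearest neighbour at 560 nM in this assay; the two values lie within the scatter of each other, so no order between them is claimed.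

Compound 3 `C[C@H](c1ccc(C(=O)NCCC(=O)O)cc1)N1C(=O)C(c2cccc(OC(F)(F)F)c2)=N[C@]12CC[C@@H](C(C)(C)C)CC2` differs from compound 2 by 3-(trifluoromethoxy)phenyl in place of 2-fluorophenyl on a carbon with a double bond to nitrogen.

Within the data shown here, only one measured step bears on this change, and only loosely: the change from compound 1 to compound 2 moved the fluorine on the same phenyl ring and gave a 1.6-fold lower number from compound 1 to compound 2 (0.20 log units; within the scatter). Among the measured compounds shown here, no measured step replaces a fluorine with a trifluoromethoxy group, so the data give no direction for the present change.

For compound 3 the expectation in this assay is therefore a step of about a 1.1-fold higher number from compound 2 to compound 3 (0.06 log units; within the scatter), which is to say no change beyond the scatter, and the estimated value for compound 3 is 400 nM with a range of 130 nM to 1300 nM.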

Compound 3, half-maximal inhibitory concentration: 840 nM
The estimate for compound 3 lay 2.1-fold (0.32 log units) below the measured number; the range from low to high includes it.
By their numbers in this assay, from the lowest: compounds 2, 1 and 3 (each within the scatter of the next, the first and the last beyond it).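

In this assay, within the data shown here, 3-(trifluoromethoxy)phenyl in place of 2-fluorophenyl on the carbon with a double bond to nitrogen gives a 2.4-fold higher number from compound 2 to compound 3 (0.38 log units; beyond the scatter), the first step at this position to pass beyond the scatter, though only modestly. Trifluoromethoxy in place of fluoro on an aromatic carbon gives a 1.5-fold higher number from compound 1 to compound 3 (0.18 log units; within the scatter), so that exchange on its own shows no change that can be told from the scatter. Nothing measured here accounts for either step.

As far as these compounds go, whether the step from compound 2 follows from the change of group or from its place on the phenyl ring stays open, since the two change together in this pair. An unsubstituted phenyl, or a methoxy or amino group on that ring, would help to separate these two readings.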